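Replacing a fluorinated alkyl with a difluoroethoxy group

The source may report more compounds than this note shows. Statements on the series, on what has been measured and on what is new or still open speak of the compounds shown alone.

Of the compounds shown here, three built on a shared aminopyridine-nitrile core have been tested in an assay on isolated protein for inhibition of protein kinase C delta type (Homo sapiens), read by TR-FRET, with a stated time of 2 h; a lower number here means a stronger inhibitor, a higher number a weaker inhibitor. Compound 1 `CO[C@H]1CC[C@@H](CNc2cc(NCc3cnccc3C(F)(F)F)ncc2C#N)CC1` gives 5000 nM. Compound 2 `N#Cc1cnc(NCc2ccccc2C(F)(F)F)cc1N[C@H]1CC[C@@H](C(N)=O)CC1` gives 640 nM. Compound 3 `CC(C)(F)c1ncncc1CNc1cc(N[C@H]2CC[C@@H](O)CC2)c(C#N)cn1` gives 32 nM, the lowest of the three numbers: compound 2 gives the nearest higher number and compound 1 the furthest higher number, both gaps beyond the scatter. Since no pair among these three differs in only one place, their values are read as a whole and not as single steps.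

Compound 4 `N#Cc1cnc(NCc2cncnc2OCC(F)F)cc1N[C@H]1CC[C@@H](O)CC1` differs from compound 3 in one place: 2,2-difluoroethoxy in place of 1-fluoro-1-methylethyl on an aromatic carbon. The two groups are of similar size, without a ring, and the entering group brings one hydrogen-bond acceptor. Within the data shown here, nothing among the measured compounds isolates the effect of this swap, so the step from compound 3 to compound 4 is expected to be small, a 1.9-fold higher number from compound 3 to compound 4 (0.27 log units; within the scatter), likely within or just beyond the scatter and leaning toward a weaker inhibitor. Compound 4 is therefore estimated at 60 nM, with a range from 15 nM to 300 nM in this assay.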

Compound 4, half-maximal inhibitory concentration: 90 nM
The estimate for compound 4 lay 1.5-fold (0.18 log units) below the measured number; low and high end bracket the measured number.
By their numbers in this assay, from the lowest: compound 3; then compound 4; then compound 2; then compound 1.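

In this assay, placing 2,2-difluoroethoxy where 1-fluoro-1-methylethyl stood gives a 2.8-fold higher number from compound 3 to compound 4 (0.45 log units; beyond the scatter), the first single change that can be read among these compounds, modest in size yet beyond the scatter. It shows that this aromatic carbon, next to the ring nitrogen, can take a group that brings an oxygen and one hydrogen-bond acceptor at only a modest cost, with compound 4 still at 90 nM. No measurement at hand gives a reason for this shift.

The compounds shown leave open whether the step follows the oxygen link or the fluorine atoms, which an unfluorinated ethoxy group at this carbon would help to separate. Also open, as far as these compounds go, is how an amine such as dimethylamino, or a longer fluorinated alkoxy chain, would read at the same place.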